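From methoxy to benzyloxycarbonyl on the shared core

The source may hold more compounds than are shown below. What is called first, only, known or untested is meant among the compounds shown, and "the series" means these compounds.

compound 1 `O=C(OCc1ccccc1)c1ccc2[nH]c(-c3cn(-c4ccccc4)nc3-c3ccccc3)nc2c1` gives 12600 nM
compound 2 `COc1ccc2[nH]c(-c3cn(-c4ccccc4)nc3-c3ccc(Cl)cc3)nc2c1` gives 1760 nM

In a functional assay on MCF7 cells (Homo sapiens) for antiproliferative activity, read by MTT assay, with a stated time of 48 h (a higher number here means a weaker inhibitor, a lower number a stronger inhibitor), compound 2 holds the lower of the two numbers, at 1760 nM, and its gap to compound 1 lies beyond the scatter. Compound 3 `O=C(OCc1ccccc1)c1ccc2[nH]c(-c3cn(-c4ccccc4)nc3-c3ccc(Cl)cc3)nc2c1` has benzyloxycarbonyl in place of methoxy on an aromatic carbon of compound 2 (benzyloxycarbonyl in place of methoxy on an aromatic carbon). Compound 1, which also carries benzyloxycarbonyl, stands at 12600 nM, so a moderate rise in this assay is expected, beyond the scatter and toward weaker inhibition. The expected size is a 2.8-fold higher number from compound 2 to compound 3 (0.45 log units; beyond the scatter) in this assay. For compound 3 the estimate is 5000 nM, with an expected range from 1800 nM to 13000 nM.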

Compound 3, half-maximal inhibitory concentration: 13900 nM
Compound 3: middle estimate off by 2.8-fold (0.44 log units), on the low side, and the stated range ends below it.
By their numbers in this assay, from the lowest: compound 2; then compounds 1 and 3 (each within the scatter of the next).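

In this assay, among these compounds, benzyloxycarbonyl in place of methoxy on this aromatic carbon gives a 7.9-fold higher number from compound 2 to compound 3 (0.90 log units; beyond the scatter) as the first reading of this change alone, with chloro present on both compounds. Chloro in place of hydrogen on an aromatic carbon gives a 1.1-fold higher number from compound 1 to compound 3 (0.04 log units; within the scatter) so with benzyloxycarbonyl present, this assay does not separate the two compounds. Nothing measured here bears on the reason for either step.

Going by these compounds, whether methoxy keeps its lower number without the chloro remains open. So does how a carboxylic acid or an amine would read on this aromatic carbon.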